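Bromo to Chloro Step Repeated on a Second Core

This account rests on a few compounds, and the source may have more. Where it says the series, first, only, none or still open, it means among the compounds named here.

Measured in a functional assay on A549 cells (Homo sapiens) for inhibition, read by sulforhodamine B assay, with a stated time of 48 h; a lower number here means a stronger inhibitor of growth, a higher number a weaker inhibitor of growth:
compound 1, `COC(=O)[C@@]1(C)CCC=C2[C@@H]1CC[C@@H](C)[C@]2(C)Cc1c(C)[nH]c2c(Br)cccc12`, gives 27000 nM
compound 2, `COC(=O)[C@@]1(C)CCC=C2[C@@H]1CC[C@@H](C)[C@]2(C)Cc1c(C)[nH]c2c(Cl)cccc12`, gives 20000 nM
compound 3, `COC(=O)[C@@]1(C)CC[C@@H]2C3=C1CC[C@@H](C)[C@]3(C)Cc1c2[nH]c2c(Br)cccc12`, gives 35000 nM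

Compound 1 and compound 2 share one core and differ by chloro in place of bromo on an aromatic carbon; the step is a 1.4-fold lower number from compound 1 to compound 2 (0.13 log units; within the scatter). Compound 3 carries a different core; the difference between the two cores is not broken down here. Compound 4, `COC(=O)[C@@]1(C)CC[C@@H]2C3=C1CC[C@@H](C)[C@]3(C)Cc1c2[nH]c2c(Cl)cccc12`, is not yet measured and differs from compound 3 by chloro in place of bromo on an aromatic carbon. The surroundings of the place are not identical: in compound 1 the ring is part of a fused or bridged system of two rings, in compound 3 of five rings, so this is the same kind of change rather than the same change. For compound 4 in this assay a step of a 1.3-fold lower number from compound 3 to compound 4 (0.13 log units; within the scatter) is expected, resting on a 1.4-fold lower number from compound 1 to compound 2 (0.13 log units; within the scatter). The estimate for compound 4 is 26000 nM, in the range 12000 nM to 55000 nM.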

Compound 4, concentration for 50% growth inhibition: 21000 nM
Compound 4: the middle estimate sits 1.2-fold (0.09 log units) above what was measured; the measured number falls inside the stated range.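

In this assay the new step is a 1.7-fold lower number from compound 3 to compound 4 (0.22 log units; within the scatter), and chloro in place of bromo on an aromatic carbon reads alike on the two cores: the same change on two cores in this assay, a 1.4-fold lower number (0.13 log units; within the scatter) from compound 1 to compound 2 and a 1.7-fold lower number (0.22 log units; within the scatter) from compound 3 to compound 4, 1.2-fold (0.09 log units) apart, within the scatter of two such steps. Both steps lie within the scatter, so this change carries from one core to the other without a detectable shift. This does not show that either halogen gives the better growth inhibitor on either core, nor that a step large enough to read would carry in the same way.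

Open, going by these compounds, is whether another group on this aromatic carbon, such as fluoro, methoxy or an amine, gives a step beyond the scatter. Also open, on these data alone, is what a carboxylic acid or an amide in place of the methyl ester would do on either core.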